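A few compounds are considered here, and "the series" means these few. Any claim that something is new, unique, unknown or untested is made for them only; others in the source may bear on it.

Measured in a functional assay on Col2 cells (Homo sapiens) for cytotoxicity, read by sulforhodamine B assay; on this read-out higher numbers stand for an effect only at larger amounts of compound and lower numbers for an effect already at smaller amounts:
compound 1 `C=C1CC[C@@H]2[C@](C)(CO)[C@H](OC(C)=O)CC[C@@]2(C)[C@@H]1C/C=C1/C(=O)OC[C@H]1O`, 27.2 uM
compound 2 `C=C1CC[C@@H]2[C@](C)(CO[Si](C)(C)C(C)(C)C)[C@H](O)CC[C@@]2(C)[C@@H]1C/C=C1/C(=O)OC[C@H]1O`, 17.1 uM

On the half-maximal concentration, compound 2 holds the lower of the two numbers, yet compound 1 lies within the usual scatter of it, so the two cannot be ranked. Compound 3 `C=C1CC[C@@H]2[C@](C)(CO[Si](C)(C)C(C)(C)C)[C@H](OC(C)=O)CC[C@@]2(C)[C@@H]1C/C=C1/C(=O)OC[C@H]1O` differs from compound 2 by acetyl in place of hydrogen on an oxygen on a saturated carbon. Among the compounds with values here, no measured pair shows this change, so its size in this assay is unknown; the account expects a step that stays within the scatter, in no firm direction. The estimate for compound 3 is 20 uM, with a range from 8 uM to 50 uM. That expected step is a 1.2-fold higher number from compound 2 to compound 3 (0.07 log units; within the scatter).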

Compound 3, concentration for half-maximal effect: 11.3 uM
Estimate against measurement, compound 3: 1.8-fold (0.25 log units) above; measured number inside the range.
By their numbers in this assay, from the lowest: compounds 3, 2 and 1 (each within the scatter of the next, the first and the last beyond it).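

In this assay, acetyl in place of hydrogen on an oxygen on a saturated carbon gives a 1.5-fold lower number from compound 2 to compound 3 (0.18 log units; within the scatter) and so leaves the number unresolved from that of the free hydroxy form. Within the data shown here, the first step beyond the scatter comes from the group of 7 heavy atoms, 6 carbon and 1 silicon, in place of a hydrogen atom on an oxygen on a saturated carbon: a 2.4-fold lower number from compound 1 to compound 3 (0.38 log units; beyond the scatter) and modest in size. Nothing available explains either step. The compounds shown leave open whether a longer chain than acetyl, or an amine or a carboxylic acid, on this oxygen would shift the number. They also leave open how hydroxy and acetoxy compare when the group of 7 heavy atoms is absent.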